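A few compounds are considered here, and "the series" means these few. Any claim that something is new, unique, unknown or untested is made for them only; others in the source may bear on it.

Compound 1 `O=c1oc2ccccc2c(N2CCN(c3cccc(Cl)c3Cl)CC2)c1CO` is the reference point of the series. In a toxicity assay on HEK-293T cells (Homo sapiens) for inhibition, read by MTT assay, with a stated time of 24 h (on this read-out lower numbers stand for higher toxicity in this test and higher numbers for lower toxicity in this test), compound 1 gives > 50000 nM, which is a limit of the assay rather than a number. Compound 2 `O=c1oc2ccccc2c(N2CCN(c3ccccc3)CC2)c1CO` carries phenyl in place of 2,3-dichlorophenyl on an amine nitrogen in a ring; in this assay compound 2 gives > 50000 nM, again a limit. Compound 3 `O=c1oc2ccccc2c(N2CCN(c3ccc(F)cc3)CC2)c1CO` carries 4-fluorophenyl on that nitrogen; in this assay compound 3 gives > 50000 nM, also a limit. Accordingly a step that the two limits leave unreadable from compound 1 to compound 2, a step that the two limits leave unreadable from compound 1 to compound 3 and a step that the two limits leave unreadable from compound 2 to compound 3: none of the three steps can be sized, and all that the numbers hold is the limit of > 50000 nM in this assay, at which 3 of the 3 values shown sit.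

Compound 4 `O=c1oc2ccccc2c(N2CCN(c3cccc(Cl)c3)CC2)c1CO` is the unmeasured member. The change from compound 1 reads (hydrogen in place of chloro on an aromatic carbon). The steps from compound 1 to compound 2 and from compound 1 to compound 3 are the nearest precedents, both exchanging the whole aryl group on the amine nitrogen, and both sit at the same limit. The change to compound 4 is smaller than either. For the measured compounds named here, no measured step supplies a direction. In this assay compound 4 is therefore expected to sit at the same limit, with a step that the limit leaves unreadable from compound 1 to compound 4 expected to stay within the scatter. The estimate for compound 4 is 60000 nM, with a range from 30000 nM to 200000 nM.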

Compound 4, half-maximal cytotoxic concentration: > 50000 nM
Compound 4: no number, only a limit (the forecaster's own chance of this, stated with the estimate: 85%); the middle value lies beyond the limit too.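

Compound 4 returns a limit rather than a number in this assay, so its steps to compound 1, compound 2 and compound 3 cannot be read, and the series stands as follows: the limit of > 50000 nM in this assay, at which 4 of the 4 values shown sit.

The compounds shown leave open whether any aryl group on the amine nitrogen of the shared core would give a measurable value in this assay.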